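Ortho methoxy in the benzyl group of a sulfonylurea

This account rests on a few compounds, and the source may have more. Where it says the series, first, only, none or still open, it means among the compounds named here.

The shared core carries a dimethoxyphenyl and a substituted benzyl on the two nitrogens. Compound 1 `COc1ccc(N2C(=O)N(Cc3c(F)cc(F)cc3F)c3ccccc3S2(=O)=O)cc1OC` gives 2 nM in an assay on HEK293 cells for displacement of a labelled ligand from Orexin receptor type 2 (Homo sapiens), read by scintillation counting, with a stated time of 90 min; a higher number here means a weaker inhibitor, a lower number a stronger inhibitor. Compound 2 `COc1cc(F)c(CN2C(=O)N(c3ccc(OC)c(OC)c3)S(=O)(=O)c3ccccc32)c(Cl)c1` gives 0.1 nM, and compound 3 `COc1ccc(N2C(=O)N(Cc3c(F)cc(C)cc3Cl)c3ccccc3S2(=O)=O)cc1OC` gives 0.794 nM, which places compound 3 second highest of the three numbers, closer to compound 1 than to compound 2. Among the measured compounds shown here, the steps so far are a 20-fold lower number from compound 1 to compound 2 (1.30 log units; beyond the scatter), a 2.5-fold lower number from compound 1 to compound 3 (0.40 log units; beyond the scatter) and a 7.9-fold higher number from compound 2 to compound 3 (0.90 log units; beyond the scatter). Compound 4 `COc1ccc(N2C(=O)N(Cc3c(F)cc(F)cc3OC)c3ccccc3S2(=O)=O)cc1OC` differs from compound 3 in that (2,4-difluoro-6-methoxyphenyl in place of 2-chloro-6-fluoro-4-methylphenyl on a saturated chain carbon bound to an amide-type nitrogen in a ring). For the measured compounds named here, no measured step covers exactly this exchange: the two steps from compound 1 moved the number down with a chlorine and a methyl or methoxy, while compound 4 instead keeps two fluorines and adds a methoxy. Compound 4 is therefore expected to sit near compound 1 and compound 3, with an estimated step of a 1.5-fold higher number from compound 3 to compound 4 (0.18 log units; within the scatter) and an expected value of 1.2 nM in this assay, within a range from 0.3 nM to 5 nM.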

Compound 4, inhibition constant: 6.31 nM
Compound 4: middle estimate off by 5.3-fold (0.72 log units), on the low side; measured number outside the range, above it.
By their numbers in this assay, from the lowest: compound 2; then compound 3; then compound 1; then compound 4.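

In this assay, the 2,4-difluoro-6-methoxybenzyl group gives the weakest inhibitor of the four: a 7.9-fold higher number from compound 3 to compound 4 (0.90 log units; beyond the scatter), and a 63-fold higher number from compound 2 to compound 4 (1.80 log units; beyond the scatter). Among the compounds shown here, the single exchange of methoxy in place of fluoro on an aromatic carbon gives a 3.2-fold higher number from compound 1 to compound 4 (0.50 log units; beyond the scatter), so a methoxy on this benzyl does not always bring a lower number, as the 2-chloro-6-fluoro-4-methoxyphenyl of compound 2 had suggested. No measurement shown gives a reason for these shifts.

The compounds shown do not separate how much of the gap between compound 2 and compound 4 belongs to the chlorine and how much to where the methoxy stands. They also leave open how an ethoxy or a hydroxyl would read in place of this methoxy.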